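The source may hold more compounds than are shown below. What is called first, only, known or untested is meant among the compounds shown, and "the series" means these compounds.

Measured compounds:
compound 1, `CCCn1c(=O)c2nc(-c3cnn(Cc4ccc(F)cc4F)c3)[nH]c2n(CCC)c1=O`, "not determined" (no result reported) in an assay on CHO cells for displacement of a labelled ligand from adenosine receptor A1 (Homo sapiens); on this read-out lower numbers stand for stronger inhibition and higher numbers for weaker inhibition;
compound 2, `CCCn1c(=O)c2nc(-c3cnn(Cc4cc(C(F)(F)F)ccc4Cl)c3)[nH]c2n(CCC)c1=O`, giving 1200 nM in this assay;
compound 3, `CCCn1c(=O)c2nc(-c3cnn(Cc4c(F)cccc4F)c3)[nH]c2n(CCC)c1=O`, "not determined" (no result reported) in this assay.

On these numbers compound 3 has no single value of its own: in this assay it is one of two entries, with compound 1, for which nothing was reported. The only anchor in the set is compound 2, which in this assay gives 1200 nM, so compound 3 can be placed only by the shared core and the benzyl-linked pattern it has in common with compound 2, not by a measurement.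

Compound 4, `CCCn1c(=O)c2nc(-c3cnn(Cc4ccccc4C(F)(F)F)c3)[nH]c2n(CCC)c1=O`, differs from compound 3 in a single place: 2-(trifluoromethyl)phenyl in place of 2,6-difluorophenyl on a saturated chain carbon bound to an aromatic nitrogen. Within the data shown here, no step between two measured compounds is available to calibrate this change, and compound 3 itself has no number, so no direction can be read from the data. The expectation for compound 4 therefore rests on compound 2 and its 1200 nM alone, with a step relative to compound 3 that is taken as none beyond the scatter.

In this assay compound 4 is estimated at 1200 nM, with a range from 250 nM to 6000 nM.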

Compound 4, inhibition constant: 44 nM
Compound 4: the middle estimate sits 27-fold (1.44 log units) above what was measured; measured number outside the range, below it.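

In this assay, a 27-fold lower number from compound 2 to compound 4 (1.44 log units; beyond the scatter) shows that the substitution on the phenyl ring, on a saturated chain carbon bound to an aromatic nitrogen, strongly affects the read-out: 2-(trifluoromethyl)phenyl in place of 2-chloro-5-(trifluoromethyl)phenyl is a large step beyond the scatter. The step from the 2,6-difluorophenyl of compound 3 to the 2-(trifluoromethyl)phenyl of compound 4, like any other step involving compound 1 or compound 3, cannot be read, as neither has a number. Nothing shown gives a reason for the step.

The compounds shown leave open how a plain unsubstituted phenyl, or a phenyl carrying a methoxy group or a nitrile, would compare at this position. They also leave open whether the step holds with ethyl or butyl chains in place of the two propyl chains on the shared core.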